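The compounds below may be only part of what the source reports. "The series", "measured", "known", "first", "only" and "open" are said of these compounds alone.

Measured compounds:
- compound 1 `CC(=O)COc1cc(=O)oc2cc(OCc3cccc(Cl)c3)ccc12` — in an assay on isolated protein (strain Sprague-Dawley) for inhibition of Amine oxidase [flavin-containing] B (Rattus norvegicus), read by spectrophotometry, with a stated time of 5 min (a higher number here means a weaker inhibitor, a lower number a stronger inhibitor), compound 1 gives 26.9 nM
- compound 2 `Nc1cc(=O)oc2cc(OCc3cccc(Cl)c3)ccc12` — in this assay compound 2 gives 47.9 nM

Among the compounds with values here, compound 2 has the highest of the two numbers so far in this assay; its nearest neighbour is compound 1, and the step of a 1.8-fold higher number from compound 1 to compound 2 (0.25 log units; within the scatter) stays within the scatter, so no order between the two can be read from it.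

Compound 3 `CNc1cc(=O)oc2cc(OCc3cccc(Cl)c3)ccc12` differs from compound 2 by methyl in place of hydrogen on a nitrogen on an aromatic ring, that is, amino to methylamino.

Within the data shown here, no measured step touches a change on this nitrogen. Among the measured compounds shown here, the single step in hand, a 1.8-fold higher number from compound 1 to compound 2 (0.25 log units; within the scatter), concerns an exchange at an aromatic carbon and is itself within the scatter, so it gives no direction for the present change. With nothing in the series pointing up or down, the expectation for compound 3 is a number close to that of compound 2, with the step of a 1.1-fold lower number from compound 2 to compound 3 (0.03 log units; within the scatter) expected to fall within the scatter, and a range widened for the absence of any direct precedent.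

Compound 3 is therefore estimated at 45 nM in this assay, with a range from 15 nM to 140 nM.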

Compound 3, half-maximal inhibitory concentration: 8.71 nM
The estimate for compound 3 lay 5.2-fold (0.71 log units) above the measured number; the measured number lies below the stated range.
By their numbers in this assay, from the lowest: compound 3; then compounds 1 and 2 (each within the scatter of the next).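

In this assay, the nitrogen on the aromatic ring proves to be a place where a very small change registers: methyl in place of hydrogen gives (a 5.5-fold lower number from compound 2 to compound 3 (0.74 log units; beyond the scatter)), a step beyond the scatter, from the addition of a single carbon. The earlier exchange of amino for 2-oxopropoxy gave no readable order, but methylamino in place of 2-oxopropoxy does separate (a 3.1-fold lower number from compound 1 to compound 3 (0.49 log units; beyond the scatter)), so compound 3 has the lowest number of the three, with its steps to both others beyond the scatter. Nothing measured alongside these numbers accounts for the effect of the methyl, and the step stands as an observation only.

Three compounds leave open whether the trend continues on this nitrogen with an ethyl group, a longer chain or a second methyl, or whether the gain is specific to a single methyl. Going by these compounds, an acetyl group on the same nitrogen would also test whether the result depends on keeping an amine there, and it remains open whether the step carries over when the chlorine on the shared core is replaced by fluorine or a methoxy group.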